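The source may hold more compounds than are shown below. What is called first, only, known or untested is meant among the compounds shown, and "the series" means these compounds.

Of the compounds shown here, three with a related core have been measured in an assay on isolated protein for binding affinity to corticotropin-releasing factor receptor 1 (Homo sapiens); a lower number here means a stronger inhibitor, a higher number a weaker inhibitor. Compound 1, `CCCN(CC1CC1)c1nc(C)nc(N(CC)c2ccc(N(C)C)cc2C(F)(F)F)n1`, gives 5 nM. Compound 3, `CCCCN(CC)c1cc(C)nc(N(CC)c2ccc(I)cc2Br)n1`, gives 14 nM. Compound 2, `CCN(CC)c1cc(C)nc(N(CC)c2c(Cl)cc(OC)cc2Cl)n1`, gives 15 nM, the highest of the three numbers, though its gap to compound 3 is within the usual scatter; only its gap to compound 1 lies beyond it.

Compound 4, `CCN(CC)c1cc(C)nc(N(CC)c2c(Cl)cc(OC)cc2OC)n1`, has not yet been measured. It differs from compound 2 in one place: methoxy in place of chloro on an aromatic carbon. Among the measured compounds shown here, no pair of measured compounds shows this same change, so there is no measured step to lean on, and the expectation rests on compound 2 and the change itself. A small step toward a higher number, close to the edge of the scatter, is expected from compound 2 to compound 4, a 1.7-fold higher number from compound 2 to compound 4 (0.22 log units; within the scatter). Compound 4 is estimated to give about 25 nM in this assay, with a range from 8 nM to 80 nM.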

Compound 4, inhibition constant: 10 nM
Estimate against measurement, compound 4: 2.5-fold (0.40 log units) above; measured number inside the range.
By their numbers in this assay, from the lowest: compounds 1, 4, 3 and 2 (each within the scatter of the next, the first and the last beyond it).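

Methoxy in place of chloro on this aromatic carbon, ortho to a large group, gives a 1.5-fold lower number from compound 2 to compound 4 (0.18 log units; within the scatter) in this assay. The earlier compounds shown here differ from each other in more than one place, so they could not show this position alone; this pair shows that a swap from 1 heavy atom to 2, adding a hydrogen-bond acceptor, leaves no difference that can be told from the scatter. No measurement at hand gives a reason for this result.

Still open, as far as these compounds go, is how this position responds to groups that differ more from these two, such as an amine, a carboxylic acid or a longer ethoxy chain. The compounds shown also leave open what happens if the remaining chloro group is exchanged for methoxy too.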